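Aryl Hydrazone Variation on the Shared Urea Series

The compounds below may be only part of what the source reports. "The series", "measured", "known", "first", "only" and "open" are said of these compounds alone.

In a functional assay on U-87MG ATCC cells (Homo sapiens) for cytotoxicity, read by MTT assay, with a stated time of 72 h (a higher number here means a weaker inhibitor, a lower number a stronger inhibitor), compound 3 `COc1cc(/C=N/NC(=O)Nc2ccc(Oc3ccnc(-c4nncn4CCN(C)C)c3)c(F)c2)cc(OC)c1OC` gives 22500 nM, the highest of the three numbers. Compound 1 `CN(C)CCn1cnnc1-c1cc(Oc2ccc(NC(=O)N/N=C/c3c[nH]c4ccccc34)cc2F)ccn1` gives 690 nM in this assay, and compound 2 `CN(C)CCn1cnnc1-c1cc(Oc2ccc(NC(=O)N/N=C/c3ccccc3)cc2F)ccn1` gives 2250 nM. Compound 4 `CN(C)CCn1cnnc1-c1cc(Oc2ccc(NC(=O)N/N=C/c3ccc(O)c(O)c3)cc2F)ccn1` differs from compound 3 by 3,4-dihydroxyphenyl in place of 3,4,5-trimethoxyphenyl on a carbon with a double bond to nitrogen. All three measured steps alter the same group on that carbon: a 3.3-fold higher number from compound 1 to compound 2 (0.51 log units; beyond the scatter), a 33-fold higher number from compound 1 to compound 3 (1.51 log units; beyond the scatter) and a 10-fold higher number from compound 2 to compound 3 (1.00 log units; beyond the scatter). The step from compound 2 to compound 3 bears most directly, because a 10-fold higher number from compound 2 to compound 3 (1.00 log units; beyond the scatter) and compound 4 likewise removes the 3,4,5-trimethoxyphenyl. Compound 4 is therefore expected to show a 5.0-fold lower number from compound 3 to compound 4 (0.70 log units; beyond the scatter), a move back toward the region of compound 2 without a firm anchor for the 3,4-dihydroxyphenyl itself. Compound 4 is estimated to give 4500 nM in this assay, within a range of 1200 nM to 18000 nM.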

Compound 4, half-maximal inhibitory concentration: > 100000 nM
Compound 4 ended at the assay's limit; the forecaster's own chance of this, stated with the estimate: 5%; at least 22-fold (1.34 log units) between middle value and limit.
By their numbers in this assay, from the lowest: compound 1; then compound 2; then compound 3. At a limit, above all of these: compound 4.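

Compound 4 is a limit reading, not a number: the limit of > 100000 nM in this assay, at which 1 of the 4 values shown sits. For the compounds shown here, at this carbon, 3,4-dihydroxyphenyl gives an at least 4.4-fold higher number from compound 3 to compound 4 (0.64 log units; beyond the scatter), an at least 44-fold higher number from compound 2 to compound 4 (1.64 log units; beyond the scatter) and an at least 140-fold higher number from compound 1 to compound 4 (2.16 log units; beyond the scatter), so the position spans a wider range than the earlier compounds showed. Losing the 3,4,5-trimethoxyphenyl does not by itself bring the number back toward compound 2, and the substituted phenyl groups of compound 3 and compound 4 both sit above its plain phenyl.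

Open, going by these compounds, is whether a phenyl bearing a single hydroxyl or a single methoxy group stays near compound 2 or climbs toward compound 4. On these data alone, the true value of compound 4 beyond the limit also remains unknown.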